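This account rests on a few compounds, and the source may have more. Where it says the series, first, only, none or still open, it means among the compounds named here.

In a functional assay on the whole organism with Scenedesmus acutus as the target, read by spectrophotometry (on this read-out lower numbers stand for stronger inhibition and higher numbers for weaker inhibition), compound 3 (`S=c1s/c(=N\c2ccc(Cl)cc2)n2n1CCCC2`) gives 234 nM, within the scatter of both compound 1 (`Cc1cc(Cl)ccc1/N=c1\sc(=S)n2n1CCCC2`) at 275 nM and compound 2 (`S=c1s/c(=N\c2ccc(Br)cc2)n2n1CCCC2`) at 148 nM. The next analogue, compound 4 (`S=c1s/c(=N\c2ccccc2)n2n1CCCC2`), carries hydrogen in place of chloro on an aromatic carbon, para to a large group: hydrogen in place of chloro on an aromatic carbon. Among the compounds with values here, no measured compound lacks a halogen at that place, so this step has no direct precedent. Within the data shown here, two measured steps bear on it only indirectly. The first, a 1.2-fold lower number from compound 1 to compound 3 (0.07 log units; within the scatter), also brings in hydrogen, but in place of methyl. The second, a 1.6-fold higher number from compound 2 to compound 3 (0.20 log units; within the scatter), exchanges one halogen for another at the place that concerns compound 4. Both stay within the scatter, so neither fixes a firm size. A modest move towards a higher number in this assay, near the edge of the scatter, is therefore expected, though no step beyond the scatter would be unsurprising only with caution. The expected change is a 1.6-fold higher number from compound 3 to compound 4 (0.21 log units; within the scatter). For compound 4 the estimated value is 380 nM, with an expected range from 170 nM to 900 nM.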

Compound 4, half-maximal inhibitory concentration: 13800 nM
Compound 4: middle estimate off by 36-fold (1.56 log units), on the low side, and the stated range ends below it.
By their numbers in this assay, from the lowest: compounds 2, 3 and 1 (each within the scatter of the next); then compound 4.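

In this assay, the result shows that the place para to a large group tolerates an exchange of chloro for bromo within the scatter but not the loss of the halogen: hydrogen in place of chloro gives a 59-fold higher number from compound 3 to compound 4 (1.77 log units; beyond the scatter), and hydrogen in place of bromo gives a 93-fold higher number from compound 2 to compound 4 (1.97 log units; beyond the scatter). Within the data shown here, the loss of a single heavy atom at this place is therefore enough to produce a large step, which the earlier steps, all within the scatter, gave no sign of. Nothing available here accounts for the size of this change.

The compounds shown leave open whether a halogen is specifically required at this place or whether another group, such as fluoro, methoxy or an amine, would serve as well. They also leave open whether the same large step would appear with the methyl group of compound 1 present.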